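The source may report more compounds than this note shows. Statements on the series, on what has been measured and on what is new or still open speak of the compounds shown alone.

Compound 1, `CC(CCc1ccc(OCc2ccc3ccccc3n2)cc1)Cc1nnn[nH]1`, gives 25 nM.
Compound 2, `CCCC(CCc1nnn[nH]1)Cc1cccc(OCc2ccc3ccccc3n2)c1`, gives 11 nM.

Both compounds share a core and were tested in an assay on membranes from lung (Cavia porcellus) for binding affinity to cysteinyl leukotriene receptor (Homo sapiens); a lower number here means a stronger inhibitor, a higher number a weaker inhibitor. For the measured compounds named here, compound 1 stands as the higher of the two numbers; compound 2 gives a number that lies beyond the usual scatter below it, though no single-point step links the two structures.

Compound 3, `O=C(O)CCCCc1ccc(OCc2ccc3ccccc3n2)cc1`, has not been measured. It differs from compound 1 by 2-carboxyethyl in place of 1-((1H-tetrazol-5-yl)methyl)ethyl on a saturated chain carbon, two bonds along the chain from an aromatic carbon. Going by the values given here, no measured pair shows this change, so its size is not known from the data. A ring with four hetero atoms leaves and a shorter, ring-free group enters; on that basis a moderate shift toward a higher number is expected, rather than none, with the estimated step of a 3.2-fold higher number from compound 1 to compound 3 (0.51 log units; beyond the scatter). Compound 3 is therefore expected to give about 80 nM, within a range from 25 nM to 300 nM.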

Compound 3, inhibition constant: 110 nM
Compound 3: the middle estimate sits 1.4-fold (0.14 log units) below what was measured; measured number inside the range.
By their numbers in this assay, from the lowest: compound 2; then compound 1; then compound 3.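

In this assay, putting 2-carboxyethyl in place of 1-((1H-tetrazol-5-yl)methyl)ethyl gives a 4.4-fold higher number from compound 1 to compound 3 (0.64 log units; beyond the scatter), the first measured sign that this position responds to the group it carries. The five-membered aromatic ring with 4 hetero atoms is still not essential for a measurable result, since compound 3, which has no ring in this group, gives 110 nM. No measurement at hand explains the size of this step.

The ring and the chain that carries it change together in this single step. These data do not separate the two changes. As far as these compounds go, how an amide at this place, or a longer chain ending in a carboxylic acid, would compare also stays open.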